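From an amine chain to a sulfonate ester on the core

This account rests on a few compounds, and the source may have more. Where it says the series, first, only, none or still open, it means among the compounds named here.

Within the data shown here, in a functional assay on HCT-116 cells (Homo sapiens) for cytotoxicity, read by MTT assay, with a stated time of 72 h (a higher number here means a weaker inhibitor, a lower number a stronger inhibitor), compound 3 (`CNCCCNc1c(C(=O)NCc2ccc(F)cc2)nc(Br)c2cccnc12`) gives 9000 nM as the only true number among the three measured compounds. Compound 1 (`Nc1cccc(Nc2c(C(=O)NCc3ccc(F)cc3)nc(Br)c3cccnc23)c1`) reads > 10000 nM and this value is a limit, not a number. Compound 2 (`C[C@@H](Nc1c(C(=O)NCc2ccc(F)cc2)nc(Br)c2cccnc12)c1ccccc1`) reads > 20000 nM and this value is likewise a limit.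

Compound 4 (`Cc1ccc(S(=O)(=O)Oc2c(C(=O)NCc3ccc(F)cc3)nc(Br)c3cccnc23)cc1`) has ((4-methylphenyl)sulfonyl)oxy in place of the (3-(methylamino)propyl)amino of compound 3, on an aromatic carbon para to a bromo group (((4-methylphenyl)sulfonyl)oxy in place of (3-(methylamino)propyl)amino on an aromatic carbon). Among the measured compounds shown here, no measured compound carries this sulfonyl group, so the evidence is indirect. For the measured compounds named here, two steps bear on the change, and both alter the group on the nitrogen at this place. One is an at least 1.1-fold lower number from compound 1 to compound 3 (0.04 log units; that floor lies within the scatter) and gives no firm order. The other is an at least 2.2-fold lower number from compound 2 to compound 3 (0.34 log units; beyond the scatter) and it runs toward the chain. Compound 4 brings in an aromatic ring in place of the chain, as compound 2 does, so any shift is expected to raise the number rather than lower it. In this assay the expected change is a 1.3-fold higher number from compound 3 to compound 4 (0.12 log units; within the scatter) and no larger step is expected. Compound 4 is estimated at 12000 nM with an expected range of 4000 nM to 30000 nM for repeat measurements.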

Compound 4, half-maximal inhibitory concentration: > 20000 nM
Compound 4 gave a limit, no number (the forecaster's own chance of this, stated with the estimate: 50%); at least 1.6-fold (0.22 log units) between middle value and limit.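

In this assay, among these compounds, putting ((4-methylphenyl)sulfonyl)oxy in place of (3-(methylamino)propyl)amino on this aromatic carbon gives an at least 2.2-fold higher number from compound 3 to compound 4 (0.34 log units; beyond the scatter), the first readable step here that leaves the nitrogen link at this place. Among the four compounds, the three whose group at this place holds an aromatic ring all read as limits, whether the ring is attached through nitrogen, as in compound 1 and compound 2, or through the sulfonyl oxygen, as in compound 4, so the chain of compound 3 remains the only group here that gives a true number. The value of compound 4 is a limit, not a number, and it sits with one other compound at the same limit: the limit of > 20000 nM in this assay, at which 2 of the 4 values shown sit.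

The steps to compound 4 from compound 1 and compound 2 cannot be read, since each joins two limits, and no order among these three can be stated. The compounds shown leave open whether the loss follows from the oxygen link or from the 4-methylphenyl ring, which a 3-(methylamino)propyl chain attached through oxygen, or a methoxy group, at this place could begin to separate.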